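Cyclopropyl in place of tert-butyl on the amide of compound 2

The source may report more compounds than this note shows. Statements on the series, on what has been measured and on what is new or still open speak of the compounds shown alone.

Compound 2 `CC(C)(C)C(=O)Nc1cc(Oc2ccc(Nc3nccc4[nH]cc(-c5ccc(F)cc5)c(=O)c34)cc2F)ccn1` is tested in a functional assay on HT-29 cells (Homo sapiens) for antiproliferative activity, read by MTT assay, with a stated time of 72 h, tested at 10 uM (on this read-out lower numbers stand for less inhibition and higher numbers for more inhibition at the one concentration tested (going by the name of the read-out)), where compound 2 gives -45.8%. Going by the values given here, that is the lower of the two numbers known so far; the other belongs to compound 1 `Cn1cc(-c2ccc(F)cc2)c(=O)c2c(Nc3ccc(Oc4ccnc(NC(=O)C5CC5)c4)c(F)c3)nccc21`, which in this assay gives 24.8%, a gap beyond the usual scatter. Compound 1 and compound 2 differ in more than one place, so their two values are shown side by side without further comparison. Compound 3 `O=C(Nc1cc(Oc2ccc(Nc3nccc4[nH]cc(-c5ccc(F)cc5)c(=O)c34)cc2F)ccn1)C1CC1` has not yet been measured. It arises from compound 2 by a single change: cyclopropyl in place of tert-butyl on a carbonyl carbon. Compound 3 shares the cyclopropylcarbonyl amide with compound 1 but keeps the core of compound 2. Among the compounds with values here, with no measured step of this kind available, a modest upward step is expected in this assay, of the size a number 40.8 percentage points higher from compound 2 to compound 3 (beyond the scatter). For compound 3 the estimated value in this assay is -5%, within a range from -45% to 30%.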

Compound 3, a percentage reported as inhibition, at one concentration (the size of the read-out at that concentration, not a potency): 25.5%
Compound 3: middle estimate off by 30.5 percentage points, on the low side, within the range that was stated.
By their numbers in this assay, from the lowest: compound 2; then compounds 1 and 3 (each within the scatter of the next).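

In this assay the change from tert-butyl to cyclopropyl on the carbonyl carbon gives a number 71.3 percentage points higher from compound 2 to compound 3 (beyond the scatter) on an otherwise unchanged structure, so this position clearly affects the read-out, which the earlier pair, differing in more than one place, could not show. With the cyclopropylcarbonyl amide held constant, hydrogen in place of methyl on the aromatic nitrogen gives a number 0.7 percentage points higher from compound 1 to compound 3 (within the scatter) and so makes no difference that can be told from the scatter. Nothing at hand explains the large difference between the tert-butyl and cyclopropyl amides.

Still open, on these data alone, is how a longer chain such as n-butyl or a carbonyl substituent carrying an amine would behave at this position. Also open, as far as these compounds go, is whether methyl on the aromatic nitrogen stays without visible effect when tert-butyl sits on the amide.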